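The compounds below may be only part of what the source reports. "The series", "measured", "known", "first", "only" and "open" are said of these compounds alone.

Measured compounds:
- compound 1, `CCCC[Te]c1cccc(/C(C)=N/O)c1`, 5.12 ug/mL
- compound 2, `CCCC[Te]c1ccc(/C(C)=N/N)cc1`, 5.08 ug/mL

Both were tested in a functional assay, read by spectrophotometry, with a stated time of 30 min; a lower number here means a stronger inhibitor, a higher number a weaker inhibitor. Compound 1 gives 5.12 ug/mL there, and compound 2 gives 5.08 ug/mL; these two numbers lie within the scatter of one another, so the data do not separate them.

Compound 3, `CCCC[Te]c1cccc(C(C)N)c1`, has not yet been measured. It differs from compound 1 by a group of 3 heavy atoms (2 carbon, 1 nitrogen; no ring) in place of a group of 4 heavy atoms (2 carbon, 1 nitrogen, 1 oxygen; no ring), on an aromatic carbon. Among the compounds with values here, no measured pair in this set shows this kind of change, so there is no observed step to lean on. The two measured compounds differ from each other elsewhere and still give numbers within the scatter, which suggests that the shared core carries much of the activity. The expectation is therefore a change in this assay no larger than the scatter, as a 1.2-fold higher number from compound 1 to compound 3 (0.07 log units; within the scatter). Compound 3 is estimated at 6 ug/mL, within a range from 2.5 ug/mL to 15 ug/mL.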

Compound 3, half-maximal inhibitory concentration: 19.2 ug/mL
Compound 3: the middle estimate sits 3.2-fold (0.51 log units) below what was measured; the measured number lies above the stated range.
By their numbers in this assay, from the lowest: compounds 2 and 1 (each within the scatter of the next); then compound 3.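

In this assay, putting 1-aminoethyl on this aromatic carbon gives a 3.8-fold higher number from compound 1 to compound 3 (0.57 log units; beyond the scatter), so this position is not indifferent to what it carries and the shared core alone does not set the number. Within the data shown here, the step is modest, but it is the first change in this set that separates two compounds, and the weaker result belongs to the group without a double bond outside aromatic rings. Nothing available explains why the number rises, and the step alters several counted features at once, so none can be singled out.

From the compounds shown here alone, it remains open whether a hydroxyl in place of the amine of 1-aminoethyl would give a number closer to that of compound 1. A carboxylic acid or an amide on this aromatic carbon also remains untested among the compounds shown.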